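Adding One Hydroxy Group to Compound 2

This account rests on a few compounds, and the source may have more. Where it says the series, first, only, none or still open, it means among the compounds named here.

Cell toxicity is often checked early, and here it is measured in a toxicity assay (RAW264.7 cells) for cytotoxicity, with Mus musculus as the target, read by MTT assay, with a stated time of 4 h; on this read-out higher numbers stand for weaker inhibition and lower numbers for stronger inhibition. Of the compounds shown here, two have numbers so far. Compound 1 (`O=c1oc2c(O)cccc2cc1-c1ccc(O)c(O)c1`) gives 115000 nM. Compound 2 (`O=c1oc2c(O)c(O)ccc2cc1-c1cccc(O)c1`) gives 398000 nM, the higher of the two numbers, and the gap between them lies beyond the usual scatter of repeated measurements. Compound 2 therefore shows the weaker inhibition of this pair.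

The next compound is compound 3 (`O=c1oc2c(O)c(O)ccc2cc1-c1ccc(O)c(O)c1`). It arises from compound 2 through one change, hydroxy in place of hydrogen on an aromatic carbon: a hydroxy in place of hydrogen on an aromatic carbon, ortho to a hydroxy group and para to a large group. For the measured compounds named here, no measured pair shows what this change does on its own, so any forecast is uncertain. The one guide is compound 1 at 115000 nM, which shows that a number well under that of compound 2 is possible among these compounds. A moderate move toward stronger inhibition in this assay is expected, somewhat beyond the scatter. The estimate means a 2.7-fold lower number from compound 2 to compound 3 (0.42 log units; beyond the scatter). Compound 3 is expected at 150000 nM, within an estimated range of 50000 nM to 400000 nM.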

Compound 3, half-maximal inhibitory concentration: 97500 nM
For compound 3 the middle estimate is 1.5-fold (0.19 log units) above the measured one; the range from low to high includes it.
By their numbers in this assay, from the lowest: compounds 3 and 1 (each within the scatter of the next); then compound 2.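

In this assay, placing a hydroxy on the aromatic carbon ortho to a hydroxy group and para to a large group makes a clear difference, giving a 4.1-fold lower number from compound 2 to compound 3 (0.61 log units; beyond the scatter). The same kind of swap at another place on the molecule gives a 1.2-fold lower number from compound 1 to compound 3 (0.07 log units; within the scatter), so among these compounds, adding a hydroxy moves the number beyond the scatter at one place but not at the other, and the result depends on where the group goes rather than on the addition alone. Nothing available here explains why the two places differ.

The compounds shown leave open whether this step belongs to the hydroxy group specifically or whether another group at the same position, such as a methoxy group, a fluorine atom or an amine, would give a similar number. They also leave open whether the step would keep its size if the other hydroxy groups on the shared core were replaced by methoxy groups, since each compound here carries several hydroxy groups.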